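This account rests on a few compounds, and the source may have more. Where it says the series, first, only, none or still open, it means among the compounds named here.

Compound 1 `CC/C(=C(/c1ccc(/C=C/C(=O)O)cc1)c1ccc2[nH]ncc2c1)c1ccccc1` gives 7.2 nM in a functional assay on MCF7 cells (Homo sapiens) for antiproliferative activity, read by CellTiter-Glo, with a stated time of 5 days; on this read-out lower numbers stand for stronger inhibition and higher numbers for weaker inhibition.
Compound 2 `CC/C(=C(/c1ccc(/C=C/C(=O)O)cc1)c1ccc2c(cnn2C)c1)c1ccccc1` gives 300 nM in this assay.
Compound 3 `CC/C(=C(/c1ccc(/C=C/C(=O)O)cc1)c1ccn2nncc2c1)c1ccccc1` is recorded only as a limit in this assay, > 500 nM.

Compound 3 thus stands at the weak end of the three, at the floor of what this assay reports, as noted in the limit of > 500 nM in this assay, at which 1 of the 3 values shown sits. Compound 4 `CC/C(=C(/c1ccc(/C=C/C(=O)O)cc1)c1ccc2ocnc2c1)c1ccccc1` differs from compound 3 in one place: a group of 9 heavy atoms (7 carbon, 1 nitrogen, 1 oxygen; one five-membered aromatic ring with 2 hetero atoms, one six-membered aromatic ring of carbon only) in place of a group of 9 heavy atoms (6 carbon, 3 nitrogen; one five-membered aromatic ring with 3 hetero atoms, one six-membered aromatic ring with 1 hetero atom), on a double-bonded chain carbon bound to an aromatic carbon and a double-bonded chain carbon. Among the compounds with values here, two measured steps bear on this. The change an at least 69-fold higher number from compound 1 to compound 3 (1.84 log units; beyond the scatter) shows the group that leaves cost much against the parent, while an at least 1.6-fold higher number from compound 2 to compound 3 (0.22 log units; that floor lies within the scatter) shows that against compound 2 the gap may be small. Because an at least 1.6-fold higher number from compound 2 to compound 3 (0.22 log units; that floor lies within the scatter) is small, compound 4, which like compound 2 carries no hydrogen-bond donor, is expected near compound 2. Compound 4 is estimated at 300 nM, ranging from 60 nM to 1500 nM. The step of an at least 1.6-fold lower number from compound 3 to compound 4 (0.22 log units; that floor lies within the scatter) is therefore the expectation.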

Compound 4, half-maximal inhibitory concentration: > 500 nM
Compound 4 was reported as a limit; the forecaster's own chance of this, stated with the estimate: 35%; middle value at least 1.6-fold (0.22 log units) away from the limit.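

Like compound 3, compound 4 reaches only a limit, not a true number: the limit of > 500 nM in this assay, at which 2 of the 4 values shown sit. Set against the 1H-indazol-5-yl group, 1,3-benzoxazol-5-yl gives an at least 69-fold higher number from compound 1 to compound 4 (1.84 log units; beyond the scatter), so every replacement shown at this place falls well short of compound 1. The other readable comparison gives only a floor, an at least 1.6-fold higher number from compound 2 to compound 4 (0.22 log units; that floor lies within the scatter), and the step between compound 3 and compound 4 cannot be read.

Still open, going by these compounds, is how weak compound 3 and compound 4 really are. Also open, on these data alone, is whether 1H-indol-5-yl or 1H-benzimidazol-5-yl at this place would come close to compound 1.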